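Aryl swap on the hydrazone of the shared core

This account rests on a few compounds, and the source may have more. Where it says the series, first, only, none or still open, it means among the compounds named here.

Measured so far:
compound 1 `CN(C)CCn1cnnc1-c1cc(Oc2ccc(NC(=O)N/N=C/c3ccccc3O[N+](=O)[O-])cc2F)ccn1`: 1020 nM
compound 2 `CN(C)CCn1cnnc1-c1cc(Oc2ccc(NC(=O)N/N=C/c3ccc(F)cc3Cl)cc2F)ccn1`: 870 nM

In a functional assay on MKN-45 cells (Homo sapiens) for cytotoxicity, read by MTT assay, with a stated time of 72 h (a lower number here means a stronger inhibitor, a higher number a weaker inhibitor), compound 1 gives 1020 nM, the highest of the two numbers; compound 2 gives 870 nM and lies within the scatter. Compound 3 `CN(C)CCn1cnnc1-c1cc(Oc2ccc(NC(=O)N/N=C/c3ccc(O)cc3O)cc2F)ccn1` is not yet measured. It differs from compound 1 as follows: 2,4-dihydroxyphenyl in place of 2-(nitrooxy)phenyl on a carbon with a double bond to nitrogen. Within the data shown here, the only measured step, a 1.2-fold lower number from compound 1 to compound 2 (0.07 log units; within the scatter), also exchanges the aryl group on that same carbon and stayed within the scatter. On that basis no step beyond the scatter is expected in this assay. Compound 3 is therefore estimated at 1000 nM, with a range from 400 nM to 2500 nM. The expected step is a 1.0-fold lower number from compound 1 to compound 3 (0.01 log units; within the scatter).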

Compound 3, half-maximal inhibitory concentration: 2860 nM
Compound 3: middle estimate off by 2.9-fold (0.46 log units), on the low side; the measured number lies above the stated range.
By their numbers in this assay, from the lowest: compounds 2 and 1 (each within the scatter of the next); then compound 3.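

In this assay the aryl group on a carbon with a double bond to nitrogen does matter: 2,4-dihydroxyphenyl gives a 2.8-fold higher number from compound 1 to compound 3 (0.45 log units; beyond the scatter) and a 3.3-fold higher number from compound 2 to compound 3 (0.52 log units; beyond the scatter) in contrast to the earlier aryl exchange, which stayed within the scatter. Compound 3 is thus the weakest of the three, so this position does not tolerate every aryl swap equally. Nothing available here explains the rise. Still open, as far as these compounds go, is whether a phenyl carrying a single hydroxyl shows the same rise. Also open, from the compounds shown here alone, is whether an amine or a carboxylic acid on that phenyl moves the number the same way.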